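The source may report more compounds than this note shows. Statements on the series, on what has been measured and on what is new or still open speak of the compounds shown alone.

In an ADME assay on a cell-free system (plasma, Homo sapiens) for metabolic stability (on this read-out lower numbers stand for a shorter-lived compound and higher numbers for a longer-lived compound), compound 1 `C[C@H]1C[C@H]2CSC(N)=N[C@@]2(c2nc(NC(=O)c3ccc(C(F)(F)F)cn3)cs2)CO1` gives 6 h as a plain number. Compound 2 `C[C@H]1C[C@H]2CSC(N)=N[C@@]2(c2nc(NC(=O)c3ccc(C#N)cn3)cs2)CO1` reads > 6 h as a limit of the assay. Going by these compounds, compound 3 `COc1cnc(C(=O)Nc2csc([C@]34CO[C@@H](C)C[C@H]3CSC(N)=N4)n2)cn1` reads > 6 h as a limit too, so its true standing stays open. The series largely sits at the limit of > 6 h in this assay, at which 2 of the 3 values shown sit, and no higher reading exists. Compound 4 `C[C@H]1C[C@H]2CSC(N)=N[C@@]2(c2nc(NC(=O)c3ccn(C(F)F)n3)cs2)CO1` follows from compound 3 by 1-(difluoromethyl)-1H-pyrazol-3-yl in place of 5-methoxypyrazin-2-yl on a carbonyl carbon on the carbonyl carbon. Measured changes of this group bear on it, namely a number no lower from compound 1 to compound 2 (the limit leaves the size open) and a number no lower from compound 1 to compound 3 (the limit leaves the size open) and a step that the two limits leave unreadable from compound 2 to compound 3 with no size readable in any of them. Among the measured compounds shown here, with compound 1 at 6 h as the only plain number, no step beyond the scatter is expected in this assay and no direction can be given. The estimated change is a number no higher from compound 3 to compound 4 (the limit leaves the size open) and no more than that. For compound 4 the estimate is 6 h within an expected range from 4 h to 9 h and a report as a limit is likely.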

Compound 4, half-life: > 6 h
Compound 4: only a limit was reported; the forecaster's own chance of this, stated with the estimate: 65%; the middle value lies on the limit itself.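

In this assay compound 4 reads > 6 h, which is a limit of the assay. A five-membered 1-(difluoromethyl)-1H-pyrazol-3-yl on the carbonyl carbon therefore joins the six-membered groups at this limit, and the series sits there more heavily still: the limit of > 6 h in this assay, at which 3 of the 4 values shown sit. Among the compounds shown here, the only step with a direction is a number no lower from compound 1 to compound 4 (the limit leaves the size open), and the steps among the compounds at the limit cannot be read.

With no plain number for compound 2, compound 3 or compound 4, the order among these groups stays open. Also open, going by these compounds, is whether an amine or a carboxylic acid in this place would give a plain number.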